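Methoxy for nitro on the triazole aryl group: tolerability outlook

A few compounds are considered here, and "the series" means these few. Any claim that something is new, unique, unknown or untested is made for them only; others in the source may bear on it.

Measured so far in an ADME assay on HepG2 cells (Homo sapiens) for cytotoxicity, read by MTT assay, with a stated time of 24 h; a higher number here means that more compound is tolerated, a lower number that less compound is tolerated:
Compound 1, `CC(C)=CCC1=C(OCc2cn(Cc3ccccn3)nn2)C(=O)c2ccccc2C1=O`: 658000 nM
Compound 2, `CC(C)=CCC1=C(OCc2cn(-c3cccc(F)c3)nn2)C(=O)c2ccccc2C1=O`: 265000 nM
Compound 3, `CC(C)=CCC1=C(OCc2cn(-c3ccc([N+](=O)[O-])cc3)nn2)C(=O)c2ccccc2C1=O`: 540000 nM

Compound 3 stands second highest of the three numbers in this assay. Its nearest neighbour is compound 1, whose number differs from compound 3 by a step within the scatter a 1.2-fold lower number from compound 1 to compound 3 (0.09 log units; within the scatter). Compound 2 lies further off, and the step of a 2.0-fold higher number from compound 2 to compound 3 (0.31 log units; beyond the scatter) is modest but beyond the scatter. The change on the aromatic nitrogen between compound 1 and compound 2 gave a modest step, a 2.5-fold lower number from compound 1 to compound 2 (0.39 log units; beyond the scatter).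

Compound 4 is `COc1ccc(-n2cc(COC3=C(CC=C(C)C)C(=O)c4ccccc4C3=O)nn2)cc1`. It differs from compound 3 in one place: methoxy in place of nitro on an aromatic carbon. For the measured compounds named here, no measured step alters a group on the phenyl ring in this way; the nearest precedent is the exchange of one aryl group for another, which gave only modest steps. A change of this size is therefore expected, at most: a 1.1-fold lower number from compound 3 to compound 4 (0.03 log units; within the scatter), most likely within the scatter. Compound 4 is expected to give about 500000 nM in this assay, within a range from 250000 nM to 1000000 nM.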

Compound 4, half-maximal cytotoxic concentration: 200000 nM
Compound 4: the middle estimate sits 2.5-fold (0.40 log units) above what was measured; the whole stated range lies above it.
By their numbers in this assay, from the lowest: compounds 4 and 2 (each within the scatter of the next); then compounds 3 and 1 (each within the scatter of the next).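

In this assay, methoxy in place of nitro on this aromatic carbon, para to a large group, gave a 2.7-fold lower number from compound 3 to compound 4 (0.43 log units; beyond the scatter) and so showed that a change on the phenyl ring alone can move the number beyond the scatter. The 4-methoxyphenyl group gave a 1.3-fold lower number from compound 2 to compound 4 (0.12 log units; within the scatter) against the 3-fluorophenyl group and a 3.3-fold lower number from compound 1 to compound 4 (0.52 log units; beyond the scatter) against (pyridin-2-yl)methyl on the aromatic nitrogen. An aryl group on that nitrogen therefore does not fix the number by itself: compound 2 and compound 4 lie beyond the scatter of compound 1, while compound 3, also an aryl compound, stays within it.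

The compounds shown leave open whether an amine, a chlorine or a methoxy group on another ring carbon would follow nitro or methoxy here. Nothing available explains why the nitro-to-methoxy exchange gave this step.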